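Demethylating compound 3: an aryl methoxy turned hydroxy

The source may report more compounds than this note shows. Statements on the series, on what has been measured and on what is new or still open speak of the compounds shown alone.

Of the compounds shown here, three sharing one core have been tested in a functional assay on SK-MEL-2 cells (Homo sapiens) for inhibition, read by sulforhodamine B assay, with a stated time of 48 h; on this read-out higher numbers stand for lower toxicity in this test and lower numbers for higher toxicity in this test. Among the compounds with values here, compound 3, `COc1cc(-c2nn(-c3cccc(NC(=O)Nc4ccc(Cl)c(C(F)(F)F)c4)c3)cc2-c2ccncc2)ccc1Cl`, is the only one with a number: in this assay compound 3 gives 17500 nM. Compound 1, `O=C(Nc1cccc(-n2cc(-c3ccncc3)c(-c3ccc(Cl)c(O)c3)n2)c1)Nc1cccc(C(F)(F)F)c1`, gives only a limit in this assay, > 32500 nM. Compound 2, `O=C(Nc1cccc(-n2cc(-c3ccncc3)c(-c3ccc(Cl)c(O)c3)n2)c1)Nc1ccc(Cl)c(Cl)c1`, likewise gives only a limit in this assay, > 32500 nM. The step from compound 1 to compound 2, a step that the two limits leave unreadable from compound 1 to compound 2, cannot be sized for this reason.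

Compound 4, `O=C(Nc1cccc(-n2cc(-c3ccncc3)c(-c3ccc(Cl)c(O)c3)n2)c1)Nc1ccc(Cl)c(C(F)(F)F)c1`, differs from compound 3 in one place: hydrogen in place of methyl on an oxygen on an aromatic ring. Within the data shown here, no measured step covers this change. The nearest hint is the limit of > 32500 nM in this assay, at which 2 of the 3 values shown sit, and both compounds at that limit carry the hydroxy group that enters in compound 4. Compound 4 is therefore expected to lie at or past that limit, and the expected step of a 2.0-fold higher number from compound 3 to compound 4 (0.30 log units; within the scatter) would be toward lower toxicity, though a result within scatter of compound 3 cannot be excluded. The estimate for compound 4 in this assay is 35000 nM, with a range from 14000 nM to 90000 nM.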

Compound 4, concentration lethal to 50% of the cells: 5840 nM
Compound 4: the middle estimate sits 6.0-fold (0.78 log units) above what was measured; measured number below the stated range.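

The methoxy to hydroxy change gives, in this assay, a 3.0-fold lower number from compound 3 to compound 4 (0.48 log units; beyond the scatter), which here means higher toxicity in this test. With the hydroxy group in place, changes elsewhere on the molecule also count: trifluoromethyl in place of chloro gives an at least 5.5-fold lower number from compound 2 to compound 4 (0.74 log units; beyond the scatter), and chloro in place of hydrogen gives an at least 5.5-fold lower number from compound 1 to compound 4 (0.74 log units; beyond the scatter). Compound 4 carries the same hydroxy group as compound 1 and compound 2, so that group alone does not hold a compound at the assay limit: the limit of > 32500 nM in this assay, at which 2 of the 4 values shown sit.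

Going by these compounds, only methoxy and hydroxy appear at this position, so how an amine or an ethoxy group there would read remains open. Compound 1 and compound 2 have no methoxy partner among the compounds shown, so whether the change gives a similar step alongside their groups also remains open.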